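Solubility of a pyrazolopyridine pair and a propyl analogue

This account rests on a few compounds, and the source may have more. Where it says the series, first, only, none or still open, it means among the compounds named here.

Measured so far:
compound 1, `CCc1ccc(-c2nc3c(c(C)nn3-c3ccccc3)c(-c3ccccc3C#N)c2C#N)cc1`, 2400 nM
compound 2, `Cc1cccc(-c2nc3c(c(C)nn3-c3ccccc3)c(-c3ccccc3O)c2C#N)c1`, 42000 nM

Both compounds were tested in a physicochemical assay for solubility, read by spectrophotometry, in phosphate buffer, with a stated time of 18 h, at pH 7.4; a higher number here means a more soluble compound, a lower number a less soluble compound. Compound 2 gives 42000 nM, the higher of the two numbers. The nearest comparison is compound 1, which in this assay gives 2400 nM, a gap well beyond the usual scatter; the two compounds differ in more than one place, so no single change can be tied to that gap.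

Compound 3, `CCCc1ccc(-c2nc3c(c(C)nn3-c3ccccc3)c(-c3ccccc3O)c2C#N)cc1`, has not yet been measured. It keeps the 2-hydroxyphenyl group of compound 2 and differs from it at one position: 4-propylphenyl in place of 3-methylphenyl on an aromatic carbon. The change is a 4-propylphenyl group in place of a 3-methylphenyl group on an aromatic carbon of the shared core.

Among the measured compounds shown here, no measured pair shows what such a swap does here, so the expectation rests on compound 2 alone. A modest fall in solubility is expected, which would amount to an estimated step of a 2.8-fold lower number from compound 2 to compound 3 (0.45 log units; beyond the scatter). Compound 3 is estimated at 15000 nM, with a likely range from 4000 nM to 50000 nM.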

Compound 3, solubility: 6500 nM
Compound 3: middle estimate off by 2.3-fold (0.36 log units), on the high side; the range from low to high includes it.
By their numbers in this assay, from the lowest: compound 1; then compound 3; then compound 2.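

Among the compounds shown here, this pair gives the first reading of a single change at this position, the aromatic carbon next to the ring nitrogen of the shared core: in this assay, putting 4-propylphenyl in place of 3-methylphenyl gives a 6.5-fold lower number from compound 2 to compound 3 (0.81 log units; beyond the scatter). The step is clear even though both groups are six-membered aromatic rings of carbon only, with no hydrogen-bond donors or acceptors and no net charge; what differs is the size of the group, 9 heavy atoms against 7, and where its chain sits on the ring. No measurement among these compounds accounts for the size or direction of this step.

Since the chain and its attachment point change together in this one pair, the compounds shown cannot separate the effect of the longer propyl chain from that of moving from the 3 position to the 4 position of the phenyl ring. Also open, from the compounds shown here alone, is how the number would respond to a group of a different kind at this position, such as a phenyl ring carrying an amine or a carboxylic acid.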